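The compounds below may be only part of what the source reports. "The series", "measured", "known", "first", "only" and "open" are said of these compounds alone.

Series notes, measured in a physicochemical assay for solubility, measured as kinetic solubility, with a stated time of 1 h, at pH 7.4; on this read-out lower numbers stand for lower solubility and higher numbers for higher solubility:
- compound 1 `CC(=O)Nc1nc(-c2ccc(Cl)cc2)cs1`: 1000 nM
- compound 2 `NC1=NN(c2ccc(Cl)c(Cl)c2)CC1`: 69000 nM
- compound 3 `CC(=O)NC1=NN(c2ccc(Cl)c(Cl)c2)CC1`: 31000 nM

Compound 3 holds the second highest of the three numbers, under compound 2 and over compound 1, and the gap to compound 1 is much the wider. Compound 4 `CC(=O)N[C@@H](C)C(=O)NC1=NN(c2ccc(Cl)c(Cl)c2)CC1` is the next to be read in this assay. Its change from compound 3 is 1-acetamidoethyl in place of methyl on a carbonyl carbon.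

Going by the values given here, only one measured step bears on this: a 2.2-fold lower number from compound 2 to compound 3 (0.35 log units; beyond the scatter), a modest step with acetyl in place of hydrogen on an amine nitrogen. It is a different change, and compound 1 offers no matched comparison. One modest step gives weak support for any direction, so only a slight lean to a lower number is taken from it. The expected step, a 1.6-fold lower number from compound 3 to compound 4 (0.19 log units; within the scatter), is none beyond the scatter.

For compound 4 the expected value is 20000 nM, with an estimated range of 6000 nM to 60000 nM.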

Compound 4, solubility: 58000 nM
For compound 4 the middle estimate is 2.9-fold (0.46 log units) below the measured one; the measured number falls inside the stated range.
By their numbers in this assay, from the lowest: compound 1; then compounds 3, 4 and 2 (each within the scatter of the next, the first and the last beyond it).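

On a carbonyl carbon whose other neighbour is an amide-type nitrogen, 1-acetamidoethyl in place of methyl gives, in this assay, a 1.9-fold higher number from compound 3 to compound 4 (0.27 log units; within the scatter) and so leaves the read-out within the scatter. Going by these compounds alone, this position therefore accepts a chain of 6 heavy atoms, with a hydrogen-bond donor, a hydrogen-bond acceptor and a defined stereocentre, without a step beyond the scatter, which the earlier compounds could not show because none carried a substituent here larger than methyl. No measurement offered here accounts for this result.

Still open, from the compounds shown here alone, is whether the opposite configuration at the stereocentre reads the same as compound 4. Also open, going by these compounds, is whether a free amine or a carboxylic acid in place of the terminal acetamido group, or a longer chain, would stay within the scatter of compound 3.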